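Cyclobutyl on the Aromatic Nitrogen: Expected Cell Tolerance

The source may report more compounds than this note shows. Statements on the series, on what has been measured and on what is new or still open speak of the compounds shown alone.

Compound 1 `CN1C(=S)[C@@H](NC(=O)c2n[nH]c(Cc3ccccc3)n2)COc2ccccc21` is one of three close relatives tested in a toxicity assay on HT-29 cells (Homo sapiens) for cytotoxicity; a higher number here means that more compound is tolerated, a lower number that less compound is tolerated. For compound 1 the result is only a limit, > 50000 nM. Compound 2 `CN1C(=S)[C@@H](NC(=O)c2nc(Cc3ccccc3)n(CCCC(F)(F)F)n2)COc2ccccc21` also stops at a limit, > 100000 nM. Compound 3 `CN1C(=S)[C@@H](NC(=O)c2nc(Cc3ccccc3)n(CCCCC#N)n2)COc2ccccc21` likewise gives a limit, > 100000 nM. The steps a step that the two limits leave unreadable from compound 1 to compound 2, a step that the two limits leave unreadable from compound 1 to compound 3 and a step that the two limits leave unreadable from compound 2 to compound 3 therefore have no readable size. Compound 4 `CN1C(=S)[C@@H](NC(=O)c2nc(Cc3ccccc3)n(C3CCC3)n2)COc2ccccc21` differs from compound 1 by cyclobutyl in place of hydrogen on an aromatic nitrogen. The two measured steps that replace hydrogen on an aromatic nitrogen show no size, so in this assay no step beyond the scatter is expected in either direction. Compound 4 is expected to give about 100000 nM, between 40000 nM and 300000 nM, most likely again as a limit, which means an expected step that the limit leaves unreadable from compound 1 to compound 4.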

Compound 4, half-maximal cytotoxic concentration: > 100000 nM
Compound 4 was reported as a limit; the forecaster's own chance of this, stated with the estimate: 85%; the middle value lies on the limit itself.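

Compound 4 stops at a limit, > 100000 nM, so its steps from compound 1, compound 2 and compound 3 cannot be read in this assay. The compounds shown leave open at what concentration any of them becomes toxic to these cells.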